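Benzyl for chlorophenyl on the bromoacrylamide arm

The compounds below may be only part of what the source reports. "The series", "measured", "known", "first", "only" and "open" are said of these compounds alone.

Measured so far:
compound 1 `Nc1cccc(-c2cn3nc(Cc4ccccc4)sc3n2)c1` — 24000 nM
compound 2 `C=C(Br)C(=O)Nc1cccc(-c2cn3nc(-c4ccc(Cl)cc4)sc3n2)c1` — 3000 nM
compound 3 `Nc1cccc(-c2cn3nc(-c4ccc(Cl)cc4)sc3n2)c1` — 160000 nM

All three numbers come from a functional assay on HeLa cells (Homo sapiens) for inhibition, read by cell counting, with a stated time of 4 days; on this read-out higher numbers stand for weaker inhibition and lower numbers for stronger inhibition. Compound 2 gives the lowest number of the three; compound 1 stands nearest to it and compound 3 furthest, the latter gap being a 53-fold higher number from compound 2 to compound 3 (1.73 log units; beyond the scatter).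

Compound 4 `C=C(Br)C(=O)Nc1cccc(-c2cn3nc(Cc4ccccc4)sc3n2)c1` differs from compound 2 in one place: benzyl in place of 4-chlorophenyl on an aromatic carbon.

For the measured compounds named here, one measured step bears directly on this exchange, run the other way on the free amines: a 6.7-fold higher number from compound 1 to compound 3 (0.82 log units; beyond the scatter). The step of a 53-fold higher number from compound 2 to compound 3 (1.73 log units; beyond the scatter) concerns the acyl group only and says nothing about the aryl exchange. If the aryl exchange acts on the acylated pair as it did on the amines, a lower number is expected for compound 4, of a size comparable to the amine step, though only one such pair supports this.

Compound 4 is therefore expected at 450 nM, within 150 nM to 1500 nM. This corresponds to an expected step of a 6.7-fold lower number from compound 2 to compound 4 (0.82 log units; beyond the scatter).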

Compound 4, half-maximal inhibitory concentration: 4500 nM
Compound 4: the middle estimate sits 10-fold (1.00 log units) below what was measured; the whole stated range lies below it.
By their numbers in this assay, from the lowest: compounds 2 and 4 (each within the scatter of the next); then compound 1; then compound 3.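

On the acylated amines in this assay, benzyl and 4-chlorophenyl on this aromatic carbon are not separated, with a 1.5-fold higher number from compound 2 to compound 4 (0.18 log units; within the scatter), so the preference for benzyl seen on the free amines does not carry over to the (1-bromoethenyl)carbonyl amides: the same change on two cores in this assay, a 6.7-fold higher number (0.82 log units; beyond the scatter) from compound 1 to compound 3 and a 1.5-fold lower number (0.18 log units; within the scatter) from compound 4 to compound 2, 10-fold (1.00 log units) apart, beyond the scatter of two such steps. The acyl group also lowers the number with benzyl in place, with a 5.3-fold lower number from compound 1 to compound 4 (0.73 log units; beyond the scatter), but its step depends on the group at this position: the same change on two cores in this assay, a 53-fold higher number (1.73 log units; beyond the scatter) from compound 2 to compound 3 and a 5.3-fold higher number (0.73 log units; beyond the scatter) from compound 4 to compound 1, 10-fold (1.00 log units) apart, beyond the scatter of two such steps. In these four compounds, the two changes therefore do not add independently.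

The compounds shown leave open whether the same dependence appears with other groups at this position, such as cyclohexyl or phenethyl. They also leave open whether the bromine is needed, which an acetyl or unsubstituted acryloyl group on the same nitrogen would test.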